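Aryl group directly on the core ring in place of the ether chain

This account rests on a few compounds, and the source may have more. Where it says the series, first, only, none or still open, it means among the compounds named here.

Measured compounds:
compound 1 `Cc1nn(-c2ncnc3nc[nH]c23)c2c1C(OCC(=O)c1ccc(F)cc1)CC(=O)N2`: 973 nM
compound 2 `Cc1nn(-c2ncnc3nc[nH]c23)c2c1C(OCc1ccccc1F)CC(=O)N2`: 78 nM
compound 3 `Cc1cc(C)n(CCOC2CC(=O)Nc3c2c(C)nn3-c2ncnc3nc[nH]c23)n1`: 2000 nM

In a functional assay on HEK293 cells for agonist activity at G-protein coupled receptor 39 (Homo sapiens), read by scintillation proximity assay and inositol phosphate accumulation, with a stated time of 75 min (a lower number here means that less compound is needed, a higher number that more compound is needed for the effect), compound 3 gives the highest number of the three. Its nearest neighbour is compound 1, with a 2.1-fold higher number from compound 1 to compound 3 (0.31 log units; beyond the scatter); compound 2 lies furthest away, with a 26-fold higher number from compound 2 to compound 3 (1.41 log units; beyond the scatter).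

Compound 4 `Cc1nn(-c2ncnc3nc[nH]c23)c2c1C(c1ccc(OC(C)C)cc1)CC(=O)N2` is not yet measured. The change from compound 3 is a group of 10 heavy atoms (9 carbon, 1 oxygen; one six-membered aromatic ring of carbon only) in place of a group of 10 heavy atoms (7 carbon, 2 nitrogen, 1 oxygen; one five-membered aromatic ring with 2 hetero atoms), on a saturated ring carbon

Going by the values given here, no measured step matches this change: all three measured steps vary the group on the saturated chain carbon bound to the oxygen, whereas here the 4-isopropoxyphenyl enters on the saturated ring carbon itself. The measured steps show that this region of the molecule tolerates large swings in either direction, a 12-fold lower number from compound 1 to compound 2 (1.10 log units; beyond the scatter) and a 26-fold higher number from compound 2 to compound 3 (1.41 log units; beyond the scatter), so a step beyond the scatter is likely but its direction is not fixed by the data. Since compound 3 is the weakest of the three, the step for compound 4 is estimated as a 5.0-fold lower number from compound 3 to compound 4 (0.70 log units; beyond the scatter), towards a lower number. Compound 4 is therefore expected to give 400 nM, with a wide range from 60 nM to 3000 nM.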

Compound 4, half-maximal effective concentration: 2700 nM
For compound 4 the middle estimate is 6.8-fold (0.83 log units) below the measured one; low and high end bracket the measured number.
By their numbers in this assay, from the lowest: compound 2; then compound 1; then compounds 3 and 4 (each within the scatter of the next).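

In this assay, 4-isopropoxyphenyl directly on the saturated ring carbon gives a 1.4-fold higher number from compound 3 to compound 4 (0.13 log units; within the scatter), so this exchange for the ether chain bearing the dimethylpyrazole does not separate the two compounds. Against the (2-fluorobenzyl)oxy group at the same ring carbon, the picture differs, with a 35-fold higher number from compound 2 to compound 4 (1.54 log units; beyond the scatter), so 4-isopropoxyphenyl does not keep the low number of compound 2 in this series. Nothing available here accounts for either step.

On these data alone, whether a 2-fluorophenyl group set directly on the saturated ring carbon, with no ether oxygen, would read like 4-isopropoxyphenyl or like (2-fluorobenzyl)oxy stays open. Also open, as far as these compounds go, is how a methoxy group, an amine or a carboxylic acid would read in place of the isopropoxy group on that phenyl ring.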